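Oxolane in place of dioxolane: an untested exchange

A few compounds are considered here, and "the series" means these few. Any claim that something is new, unique, unknown or untested is made for them only; others in the source may bear on it.

Compound 2 `CCN(CC)c1ccc(NC(=O)c2c(-c3c(Cl)cccc3Cl)noc2CCC2OCCO2)cc1` gives 25 nM in an in vitro assay on CHO-K cells with growth hormone secretagogue receptor type 1 (Homo sapiens) as the target; on this read-out higher numbers stand for weaker inhibition and lower numbers for stronger inhibition. Among the two compounds measured so far it holds the highest number: compound 1 `CCN(CC)c1ccc(NC(=O)c2c(-c3c(Cl)cccc3Cl)noc2CCC2OCCCO2)cc1` gives 6 nM in this assay, and the step of a 4.2-fold higher number from compound 1 to compound 2 (0.62 log units; beyond the scatter) exchanges one saturated ring for another at the same chain position. Compound 3 `CCN(CC)c1ccc(NC(=O)c2c(-c3c(Cl)cccc3Cl)noc2CCC2CCCO2)cc1` carries the change (oxolan-2-yl in place of 1,3-dioxolan-2-yl on a saturated chain carbon, two bonds along the chain from an aromatic carbon). Among the compounds with values here, no measured step bears directly on this exchange; the single step of a 4.2-fold higher number from compound 1 to compound 2 (0.62 log units; beyond the scatter) concerns the size of the ring and keeps both ring oxygens, whereas the move to compound 3 keeps the ring size and removes one of the ring oxygens. With nothing to anchor a direction, the estimate for compound 3 rests on compound 2 alone, and no step beyond the scatter is expected. Compound 3 is therefore estimated at 25 nM in this assay, with a range from 7 nM to 90 nM, which corresponds to an expected step of no change at the digits printed from compound 2 to compound 3 (within the scatter) from compound 2.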

Compound 3, half-maximal inhibitory concentration: 57 nM
Compound 3: middle estimate off by 2.3-fold (0.36 log units), on the low side; the measured number falls inside the stated range.
By their numbers in this assay, from the lowest: compound 1; then compound 2; then compound 3.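

At this chain position, the ring atoms matter as well as the ring size: with the five-membered ring kept and 1,3-dioxolan-2-yl exchanged for oxolan-2-yl, this assay shows a 2.3-fold higher number from compound 2 to compound 3 (0.36 log units; beyond the scatter), so the number moves even though the heavy-atom count stays the same. The two changes seen so far point the same way, since the smaller ring and the ring with one oxygen each give a higher number, and the route that combines them gives a 9.5-fold higher number from compound 1 to compound 3 (0.98 log units; beyond the scatter), the widest gap among these three compounds. No measurement on hand explains why the number rises with either change.

The three compounds leave open how far ring size and ring oxygen count act independently, as an oxan-2-yl group, with a six-membered ring and one oxygen, would complete the comparison. They also leave open whether the number would continue to rise with a cyclopentyl group, which has no ring oxygen, or how an amine or a longer chain at this position would read.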